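Adding octylamino to compound 2

The compounds below may be only part of what the source reports. "The series", "measured", "known", "first", "only" and "open" are said of these compounds alone.

Among the compounds with values here, in an ADME assay on HaCaT cells (Homo sapiens) for cytotoxicity, read by MTT assay, with a stated time of 72 h (on this read-out lower numbers stand for stronger inhibition and higher numbers for weaker inhibition), compound 2 (`CC1=CCC[C@H]2[C@](C)(CC3=CC(=O)C=CC3=O)[C@@H](C)CC[C@]12C`) gives 37000 nM, the only exact number so far. Compound 1 (`CCCCNC1=CC(=O)C(C[C@]2(C)[C@@H](C)CC[C@]3(C)C(C)=CCC[C@@H]23)=CC1=O`) gives > 100000 nM, which is a limit of the assay and not a number. Compound 3 (`CCCCCCCCNC1=CC(=O)C(C[C@]2(C)[C@@H](C)CC[C@]3(C)C(C)=CCC[C@@H]23)=CC1=O`) carries octylamino in place of hydrogen on a double-bonded ring carbon. Within the data shown here, the one measured step that bears on this, hydrogen replacing butylamino, was an at least 2.7-fold lower number from compound 1 to compound 2 (0.43 log units; beyond the scatter), so adding an amino chain back is expected to raise the number, though no measured compound carries the longer chain. The expected change is a 1.6-fold higher number from compound 2 to compound 3 (0.21 log units; within the scatter). For compound 3 the estimate is 60000 nM, with a range of 20000 nM to 120000 nM.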

Compound 3, half-maximal inhibitory concentration: > 100000 nM
Compound 3: only a limit was reported; the forecaster's own chance of this, stated with the estimate: 40%; middle value at least 1.6-fold (0.22 log units) away from the limit.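

In this assay, octylamino in place of hydrogen gives an at least 2.7-fold higher number from compound 2 to compound 3 (0.43 log units; beyond the scatter). Butylamino and octylamino therefore both go with a higher number than hydrogen on this double-bonded ring carbon, so the earlier result is not confined to one chain. The step from compound 1 to compound 3 cannot be read, because both compounds give only a limit: the limit of > 100000 nM in this assay, at which 2 of the 3 values shown sit.

As far as these compounds go, whether chain length matters at this position stays open. A shorter chain such as methylamino, or a ring amine such as morpholine, might give an exact number in this assay.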